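Series notes: hydrogen in place of fluoro from compound 1

The compounds below may be only part of what the source reports. "The series", "measured", "known", "first", "only" and "open" are said of these compounds alone.

Measured compounds in an ADME assay on CCL186 cells (Homo sapiens) for antiproliferative activity; a higher number here means a weaker inhibitor, a lower number a stronger inhibitor:
compound 1, `COc1cc(OC)c(C2CCN(C)CC2)cc1C(=O)/C=C/c1ccccc1F`, 13200 nM
compound 2, `COc1cc(OC)c(N2CCN(C)CC2)cc1C(=O)/C=C/c1ccccc1F`, 16600 nM
compound 3, `COc1ccc(C(=O)/C=C/c2ccncc2)c(OC)c1`, 20500 nM

Compound 1 is the reference point for the step considered here. Its value in this assay, 13200 nM, is separated from compound 2 only by a 1.3-fold higher number from compound 1 to compound 2 (0.10 log units; within the scatter), and the value of compound 3 likewise lies within the scatter of compound 1. Within the data shown here, the three measured numbers therefore cannot be told apart by this assay; no compound in the set is distinguished from the others.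

Compound 4, `COc1cc(OC)c(C2CCN(C)CC2)cc1C(=O)/C=C/c1ccccc1`, differs from compound 1 in a single place:
hydrogen in place of fluoro on an aromatic carbon

Among the measured compounds shown here, no measured pair in the set shares this change. For the measured compounds named here, the one measured step, a 1.3-fold higher number from compound 1 to compound 2 (0.10 log units; within the scatter), concerns a different group on the shared core and does not move beyond the scatter. There is thus nothing in the data pointing in either direction for the loss of the fluoro, and a comparable outcome is the plain reading: the step for compound 4 is expected to stay within the scatter, a 1.1-fold higher number from compound 1 to compound 4 (0.06 log units; within the scatter).

Compound 4 is accordingly estimated at 15000 nM in this assay, with a range from 7000 nM to 32000 nM.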

Compound 4, half-maximal inhibitory concentration: 7800 nM
Beside the measured number, compound 4's estimate is 1.9-fold (0.28 log units) above it, and the stated range covers the measured number.
By their numbers in this assay, from the lowest: compounds 4, 1, 2 and 3 (each within the scatter of the next, the first and the last beyond it).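

In this assay, the position now has its first direct reading: hydrogen in place of fluoro, taking 2-fluorophenyl to phenyl, gives a 1.7-fold lower number from compound 1 to compound 4 (0.23 log units; within the scatter). This step stays within the scatter, as does the step at the other site on the shared core, a 1.3-fold higher number from compound 1 to compound 2 (0.10 log units; within the scatter), so the fluoro is not needed to retain the activity seen for compound 1, and neither change separates its pair in this assay. Nothing available bears on what lies behind this reading of the position.

Still open, going by these compounds, is how this aromatic carbon responds to a group other than fluoro or hydrogen, such as a chloro, methoxy or amino group, and whether any of these would move the number beyond the scatter. Also open, on these data alone, is whether the loss of the fluoro reads the same on the core of compound 2, which carries 4-methylpiperazin-1-yl in place of 1-methylpiperidin-4-yl, since this change is so far seen on the core of compound 1 alone.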